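Trimming the amine substituent on a tryptamine-piperidine scaffold

This account rests on a few compounds, and the source may have more. Where it says the series, first, only, none or still open, it means among the compounds named here.

Of the compounds shown here, two sharing a piperidine-linked indole core have been measured in an assay on CHO cells for displacement of a labelled ligand from 5-hydroxytryptamine receptor 1D (Homo sapiens); on this read-out lower numbers stand for stronger inhibition and higher numbers for weaker inhibition. Compound 1 `O[C@@H]1Cc2ccccc2[C@H]1NC1CCN(CCCc2c[nH]c3ccc(-n4cnnc4)cc23)CC1` gives 6.6 nM, the highest of the two numbers. Compound 2 `CC(=O)Nc1ccc([C@H](C)NCC2CCN(CCCc3c[nH]c4ccc(-n5cnnc5)cc34)CC2)cc1`, which carries a different amine portion on the same core, gives 0.6 nM in this assay, a lower number that lies beyond the scatter.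

Compound 3 `C[C@@H](NC1CCN(CCCc2c[nH]c3ccc(-n4cnnc4)cc23)CC1)c1ccccc1` has not yet been measured. It is derived from compound 1 by the change (1-phenylethyl in place of 2-hydroxy-2,3-dihydro-1H-inden-1-yl on an amine nitrogen), that is, 1-phenylethyl in place of 2-hydroxy-2,3-dihydro-1H-inden-1-yl on an amine nitrogen. Among the measured compounds shown here, no step between measured compounds covers this exact change, so the expected direction rests on compound 2, whose value comes with a 1-arylethyl amine. Because compound 2 gives 0.6 nM with that 1-arylethyl amine, a modest downward step a 2.2-fold lower number from compound 1 to compound 3 (0.34 log units; beyond the scatter) is expected. Compound 3 is estimated at 3 nM, with a range from 0.8 nM to 12 nM.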

Compound 3, half-maximal inhibitory concentration: 0.4 nM
Beside the measured number, compound 3's estimate is 7.5-fold (0.88 log units) above it; the whole stated range lies above it.
By their numbers in this assay, from the lowest: compounds 3 and 2 (each within the scatter of the next); then compound 1.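

In this assay, among the compounds shown here, putting 1-phenylethyl in place of 2-hydroxy-2,3-dihydro-1H-inden-1-yl on the amine nitrogen gives a 17-fold lower number from compound 1 to compound 3 (1.22 log units; beyond the scatter) and is the first step read at this position with the rest of the molecule held the same. It shows that this substituent alone can move the number by a large step, which the earlier pair, differing in more than one place, could not show. The change removes the hydroxy group and the five-membered non-aromatic ring together, and nothing shown here bears on why the number falls.

Left open is how a benzyl group or a 2-hydroxy-1-phenylethyl group would read on this amine nitrogen, which would begin to separate the hydroxy group from the ring. Going by these compounds, the mirror-image form of 1-phenylethyl also remains open.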